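Moving Past the Cyano Group of Compound 2

The source may report more compounds than this note shows. Statements on the series, on what has been measured and on what is new or still open speak of the compounds shown alone.

In a functional assay on MCF7 cells (Homo sapiens) for inhibition, read by MTT assay, with a stated time of 72 h (on this read-out lower numbers stand for stronger inhibition and higher numbers for weaker inhibition), compound 1 `CCCc1ccc(NC(=O)C2CCN(C/C=C/c3ccccc3)CC2)cc1` gives 9030 nM and compound 2 `N#Cc1ccc(NC(=O)C2CCN(C/C=C/c3ccccc3)CC2)cc1` gives 44500 nM on this read-out. Among the compounds with values here, compound 2 therefore holds the higher of the two numbers, and compound 1 is its only measured neighbour. Compound 3 `CN1CCN(c2ccc(NC(=O)C3CCN(C/C=C/c4ccccc4)CC3)cc2)CC1` keeps the shared core but carries 4-methylpiperazin-1-yl in place of cyano on an aromatic carbon, para to a large group. Within the data shown here, one measured step bears on this change: the move a 4.9-fold higher number from compound 1 to compound 2 (0.69 log units; beyond the scatter) with cyano in place of propyl on an aromatic carbon, which is modest but beyond the scatter. Read in reverse, that step leads away from cyano to a lower number, so a step of similar size toward a lower number is expected from compound 2 at 44500 nM in this assay for the new group. Among the measured compounds shown here, this is a weak guide, since it rests on one pair and no compound with a ring at this place has been measured. The estimated step is a 3.0-fold lower number from compound 2 to compound 3 (0.47 log units; beyond the scatter) on that basis. For compound 3 the estimated value is 15000 nM with an expected range from 4500 nM to 45000 nM in this assay.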

Compound 3, half-maximal inhibitory concentration: 44000 nM
The estimate for compound 3 lay 2.9-fold (0.47 log units) below the measured number; the measured number falls inside the stated range.
By their numbers in this assay, from the lowest: compound 1; then compounds 3 and 2 (each within the scatter of the next).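

In this assay, 4-methylpiperazin-1-yl and cyano cannot be told apart on the aromatic carbon of the shared core (a 1.0-fold lower number from compound 2 to compound 3 (0.00 log units; within the scatter)), although the first has 7 heavy atoms and a six-membered non-aromatic ring and the second has 2 heavy atoms and no ring. The step from propyl to 4-methylpiperazin-1-yl (a 4.9-fold higher number from compound 1 to compound 3 (0.69 log units; beyond the scatter)) matches the earlier step from propyl to cyano (a 4.9-fold higher number from compound 1 to compound 2 (0.69 log units; beyond the scatter)), so compound 1 now stands apart from two different replacements, not just one. Across these three compounds, the number therefore does not follow the heavy-atom count of the group, and propyl, the only one of the three groups without nitrogen, gives the lowest number. No evidence is available to explain this separation.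

Three compounds cannot show whether the absence of nitrogen matters at this place, or whether the match between cyano and 4-methylpiperazin-1-yl extends to other groups. As far as these compounds go, a longer chain such as butyl, a carbon-only ring such as cyclohexyl, a small amine such as dimethylamino and a carboxylic acid would each test this, and where they would fall remains open.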